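From an ethyl group to a methoxy group on the outer ring

This account rests on a few compounds, and the source may have more. Where it says the series, first, only, none or still open, it means among the compounds named here.

Compound 1 `Cc1ccc(-c2ccnc(C(=O)Nc3ccc(Oc4ccnc5[nH]ccc45)c(F)c3)c2)c(C)c1` gives 4010 nM in a functional assay on PC-3 cells (Homo sapiens) for cytotoxicity, read by MTT assay, with a stated time of 72 h; on this read-out higher numbers stand for weaker inhibition and lower numbers for stronger inhibition.
Compound 2 `CCc1ccc(-c2ccnc(C(=O)Nc3ccc(Oc4ccnc5[nH]ccc45)c(F)c3)c2)cc1` gives 2960 nM in this assay.

For the measured compounds named here, compound 2 stands at the lower of the two numbers, yet the only measured step, a 1.4-fold lower number from compound 1 to compound 2 (0.13 log units; within the scatter), lies within the scatter, so the two compounds cannot be told apart. Compound 3 `COc1ccc(-c2ccnc(C(=O)Nc3ccc(Oc4ccnc5[nH]ccc45)c(F)c3)c2)cc1` differs from compound 2 by methoxy in place of ethyl on an aromatic carbon. Going by the values given here, no measured step involves a methoxy group; the one step available merely exchanged one alkyl-substituted phenyl for another without effect beyond the scatter. Compound 3 is therefore expected to remain close in this assay. The expected step is a 1.1-fold higher number from compound 2 to compound 3 (0.03 log units; within the scatter). For compound 3 the estimate is 3200 nM, ranging from 1100 nM to 9500 nM.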

Compound 3, half-maximal inhibitory concentration: 20 nM
Estimate against measurement, compound 3: 160-fold (2.20 log units) above; measured number below the stated range.
By their numbers in this assay, from the lowest: compound 3; then compounds 2 and 1 (each within the scatter of the next).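

Methoxy in place of ethyl gives a 150-fold lower number from compound 2 to compound 3 (2.17 log units; beyond the scatter) in this assay and 4-methoxyphenyl in place of 2,4-dimethylphenyl gives a 200-fold lower number from compound 1 to compound 3 (2.30 log units; beyond the scatter) on the same read-out. This place on the outer ring looked unresponsive while only alkyl-substituted rings were compared, yet it clearly depends on the group it carries. Ethyl and methoxy hold the same number of heavy atoms and differ by an oxygen for a carbon, and nothing measured here gives the cause. Still open, on these data alone, is whether a hydroxy, ethoxy or amino group in the same place would behave like methoxy.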